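A few compounds are considered here, and "the series" means these few. Any claim that something is new, unique, unknown or untested is made for them only; others in the source may bear on it.

Measured so far:
- compound 1 `O=C(Nc1ccccn1)c1c(O)c2cccnc2n(-c2ccccc2)c1=O`: -13.5%
- compound 2 `O=C(NN1CCOCC1)c1c(O)c2cccnc2n(-c2ccccc2)c1=O`: -8.5%

Both compounds were tested in a functional assay on the whole organism for inhibition, with Rattus norvegicus as the target, read by paw edema, at a dose of 100 mg/kg by the oral route; a lower number here means less inhibition, a higher number more inhibition at the dose given (going by the name of the read-out). Compound 1 gives -13.5% and compound 2 gives -8.5%; the step between them, a number 5 percentage points higher from compound 1 to compound 2 (within the scatter), is too small to count as a real difference, so the two compounds stand together within the usual scatter, their numbers level. Compound 3 `O=C(Nc1ccc([N+](=O)[O-])cc1)c1c(O)c2cccnc2n(-c2ccccc2)c1=O` is the next compound to be measured. It differs from compound 2 at the same position where compound 1 differed from it: 4-nitrophenyl in place of morpholin-4-yl on an amide-type nitrogen. Among the compounds with values here, the only step that bears on this change is a number 5 percentage points higher from compound 1 to compound 2 (within the scatter), which shows that swapping one group for another on this amide-type nitrogen did not move the number beyond the scatter. Within the data shown here, no other steps are known. On that basis, compound 3 is expected to show no change beyond the scatter, a step of a number 1.5 percentage points lower from compound 2 to compound 3 (within the scatter) in this assay. Compound 3 is therefore estimated at -10%, with a likely range from -30% to 12%.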

Compound 3, a percentage reported as inhibition, in the whole organism at one dose (the size of the read-out at that dose, not a potency): -7.6%
The estimate for compound 3 lay 2.4 percentage points below the measured number, and the stated range covers the measured number.
By their numbers in this assay, from the lowest: compounds 1, 2 and 3 (each within the scatter of the next).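

Placing 4-nitrophenyl on the amide-type nitrogen instead of morpholin-4-yl gives a number 0.9 percentage points higher from compound 2 to compound 3 (within the scatter) in this assay, and placing it there instead of pyridin-2-yl gives a number 5.9 percentage points higher from compound 1 to compound 3 (within the scatter) in the same test. Within the data shown here, three different groups, including a non-aromatic ring and an aromatic ring of carbon only, now stand level at this position, whereas the earlier compounds offered just one comparison. All three numbers are negative, so this change does not bring a positive reading in this set.

On these data alone, it remains open whether a group of another kind on this nitrogen, such as a longer chain ending in an amine or a phenyl carrying a carboxylic acid, would move the number beyond the scatter. As far as these compounds go, whether a change elsewhere on the shared core would do so is also open. No measurement at hand explains why these groups stand level.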